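Amine change from compound 3 to compound 4

The compounds below may be only part of what the source reports. "The series", "measured", "known", "first", "only" and "open" are said of these compounds alone.

Measured in a functional assay on A549 cells (Homo sapiens) for cytotoxicity, read by MTT assay, with a stated time of 72 h; a lower number here means a stronger inhibitor, a higher number a weaker inhibitor:
- compound 1 `CC1CCN(Cc2ccc3nc(NC(=O)N/N=C/c4c[nH]c5ccccc45)sc3c2)CC1`: 3580 nM
- compound 2 `Cc1ccc(Cn2cc(/C=N/NC(=O)Nc3nc4ccc(CN5CCC(C)CC5)cc4s3)c3ccccc32)cc1`: 2180 nM
- compound 3 `CN(C)Cc1ccc2nc(NC(=O)N/N=C/c3cn(Cc4ccc(Cl)cc4)c4ccccc34)sc2c1`: 840 nM

Compound 3 has the lowest of the three numbers, and its gaps to compound 1 and compound 2 both lie beyond the scatter. Compound 4 `CC1CCN(Cc2ccc3nc(NC(=O)N/N=C/c4cn(Cc5ccc(Cl)cc5)c5ccccc45)sc3c2)CC1` departs from it by one change: 4-methylpiperidin-1-yl in place of dimethylamino on a saturated chain carbon bound to an aromatic carbon, on a saturated chain carbon bound to an aromatic carbon. For the measured compounds named here, no measured step covers this change. Going by the values given here, the only step available, a 1.6-fold lower number from compound 1 to compound 2 (0.22 log units; within the scatter), concerns a substituent on an aromatic nitrogen, so it bears on the question only indirectly. The remaining evidence is thin: the two measured compounds that carry the 4-methylpiperidin-1-yl group both stand higher than compound 3, with compound 1 at 3580 nM and compound 2 at 2180 nM. Among the compounds with values here, no measured compound goes against this, though it rests on few data. A moderate rise in this assay is therefore expected, and the estimated step is a 1.8-fold higher number from compound 3 to compound 4 (0.25 log units; within the scatter). For compound 4 the expected value is 1500 nM, with an estimated range of 700 nM to 3200 nM.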

Compound 4, half-maximal inhibitory concentration: 2030 nM
For compound 4 the middle estimate is 1.4-fold (0.13 log units) below the measured one, within the range that was stated.
By their numbers in this assay, from the lowest: compound 3; then compounds 4, 2 and 1 (each within the scatter of the next).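

In this assay the swap at the saturated chain carbon bound to an aromatic carbon now has a direct reading, with 4-methylpiperidin-1-yl in place of dimethylamino giving a 2.4-fold higher number from compound 3 to compound 4 (0.38 log units; beyond the scatter) and so costing potency at this position. With 4-methylpiperidin-1-yl held in place, neither a 1.8-fold lower number from compound 1 to compound 4 (0.25 log units; within the scatter) for 4-chlorobenzyl in place of hydrogen on the aromatic nitrogen nor a 1.1-fold lower number from compound 2 to compound 4 (0.03 log units; within the scatter) for chloro in place of methyl on an aromatic carbon leaves the scatter, so in this amine setting only the amine change stands out. No measurement on hand accounts for the step at this position.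

Open, as far as these compounds go, is how piperidin-1-yl without the methyl, or morpholin-4-yl, would stand at this place with 4-chlorobenzyl kept on the aromatic nitrogen. Also open, from the compounds shown here alone, is whether dimethylamino keeps its edge with hydrogen or 4-methylbenzyl on that nitrogen.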